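Series notes: aryl-substituted thiazolidinone esters in MCF7 growth assay

The compounds below may be only part of what the source reports. "The series", "measured", "known", "first", "only" and "open" are said of these compounds alone.

Measured compounds:
compound 1 `CCOC(=O)C1=C(Nc2ccccc2)S/C(=C\c2ccc(OC)cc2)C1=O` gives 14.7% in a functional assay on MCF7 cells (Homo sapiens) for inhibition, read by MTT assay, with a stated time of 72 h, tested at 10 uM; a higher number here means more inhibition at the concentration tested (going by the name of the read-out), a lower number less inhibition
compound 2 `CCOC(=O)C1=C(Nc2ccccc2)S/C(=C\c2cc(OC)ccc2OC)C1=O` reaches only the limit < 10% in this assay
compound 3 `CCOC(=O)C1=C(Nc2ccc(F)cc2)S/C(=C\c2ccc[nH]2)C1=O` reaches only the limit < 10% in this assay

Among the compounds with values here, compound 1 carries the only numerical value in this set; for compound 2 and compound 3 the values are limits of the assay, not numbers, so no step between measured compounds can be sized. What can be said is summed up in the limit of < 10% in this assay, at which 2 of the 3 values shown sit: two of the three entries sit at that limit, and compound 1 lies a little above it.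

Compound 4 `CCOC(=O)C1=C(Nc2ccccc2)S/C(=C\c2cc3cccnc3[nH]2)C1=O` differs from compound 1 by a group of 9 heavy atoms (7 carbon, 2 nitrogen; one five-membered aromatic ring with 1 hetero atom, one six-membered aromatic ring with 1 hetero atom) in place of a group of 8 heavy atoms (7 carbon, 1 oxygen; one six-membered aromatic ring of carbon only), on a double-bonded chain carbon bound to a double-bonded ring carbon. The shared core, with its ethyl ester, the anilino substituent and the exocyclic double bond, is kept unchanged.

Within the data shown here, nothing among the measured compounds ties the aromatic group at that position to a gain in inhibition; the one numerical value, for compound 1, is low, and the other two are limits. The step from compound 1 to compound 4 is therefore expected to be small, a number 1.7 percentage points lower from compound 1 to compound 4 (within the scatter), and within the usual scatter. For compound 4 the estimate in this assay is 13%, expected to fall between 5% and 28%, with a real chance that only a limit is reported.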

Compound 4, a percentage reported as inhibition, at one concentration (the size of the read-out at that concentration, not a potency): 18.2%
Compound 4: the middle estimate sits 5.2 percentage points below what was measured; measured number inside the range.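

At the double-bonded chain carbon bound to a double-bonded ring carbon, replacing 4-methoxyphenyl with the group of one five-membered and one six-membered aromatic ring, each with 1 hetero atom, gives in this assay a number 3.5 percentage points higher from compound 1 to compound 4 (within the scatter). Within the data shown here, this is the first step at this position that can be read, and it shows that a carbon-only six-membered ring with a methoxy group and this two-ring group with its 1 hydrogen-bond donor cannot be told apart in this read-out. Compound 1 and compound 4 both remain low in inhibition at the concentration tested, so the change shows no gain, and the set as a whole still stays close to the limit of the assay: the limit of < 10% in this assay, at which 2 of the 4 values shown sit.

With a single step inside the scatter, no role can be given to the second ring, the ring nitrogens or the hydrogen-bond donor, and the steps involving compound 2 and compound 3 cannot be read, as their entries are limits and not numbers. From the compounds shown here alone, it also remains open whether a carboxylic acid or a dimethylamino group on the aromatic ring at this position, or a carboxylic acid in place of the ethyl ester, would move inhibition beyond the scatter.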